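The source may report more compounds than this note shows. Statements on the series, on what has been measured and on what is new or still open speak of the compounds shown alone.

Measured so far:
- compound 1 `COc1cc(-n2cnc3ccc(-c4ccc(C(C)=O)cc4)cc32)cc(OC)c1OC`, 450 nM in a functional assay on SGC-7901 cells (Homo sapiens) for antiproliferative activity, read by MTT assay, with a stated time of 72 h; on this read-out higher numbers stand for weaker inhibition and lower numbers for stronger inhibition
- compound 2 `COc1ccc(-c2ccc3ncn(-c4cc(OC)c(OC)c(OC)c4)c3c2)cc1F`, 430 nM in this assay

For the measured compounds named here, compound 1 gives the highest of the two numbers, yet its only neighbour lies within the scatter: a 1.0-fold lower number from compound 1 to compound 2 (0.02 log units; within the scatter). Compound 3 `COc1cc(-n2cnc3ccc(-c4ccc(C(F)(F)F)cc4)cc32)cc(OC)c1OC` differs from compound 1 at the same aromatic carbon, (trifluoromethyl in place of acetyl on an aromatic carbon). Going by the values given here, the one step that bears on this, the exchange of the whole 4-acetylphenyl for 3-fluoro-4-methoxyphenyl, moved the number hardly at all, so no step beyond the scatter is expected here either. Compound 3 is therefore estimated at 500 nM (range 160 nM to 1600 nM), an expected step of a 1.1-fold higher number from compound 1 to compound 3 (0.05 log units; within the scatter).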

Compound 3, half-maximal inhibitory concentration: 890 nM
The estimate for compound 3 lay 1.8-fold (0.25 log units) below the measured number; the range from low to high includes it.
By their numbers in this assay, from the lowest: compounds 2, 1 and 3 (each within the scatter of the next, the first and the last beyond it).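

In this assay the exchange of acetyl for trifluoromethyl on this aromatic carbon gives a 2.0-fold higher number from compound 1 to compound 3 (0.30 log units; within the scatter) and so stays at the edge of the scatter. For the compounds shown here, the change from 3-fluoro-4-methoxyphenyl to 4-(trifluoromethyl)phenyl gives a 2.1-fold higher number from compound 2 to compound 3 (0.32 log units; beyond the scatter) and is the first step here to pass the scatter, though only modestly. No measurement shown accounts for this small difference. Still open, on these data alone, is how an amine or a carboxylic acid on this carbon would compare, and whether fluorine alone or methoxy alone would give the same number as the pair in compound 2 .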